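The source may report more compounds than this note shows. Statements on the series, on what has been measured and on what is new or still open speak of the compounds shown alone.

Compound 1 `O=C(O)Cc1sc(C(c2ccc(F)cc2)c2ccc(F)cc2)nc1-c1cc(F)cc(F)c1`: in an in vitro functional assay on HEK285-7 cells for antagonist activity at prostaglandin D2 receptor 2 (Homo sapiens), read by BRET and beta-arrestin recruitment (on this read-out higher numbers stand for weaker inhibition and lower numbers for stronger inhibition), compound 1 gives 340 nM.
Compound 2 `O=C(O)Cc1sc(C(c2ccc(F)cc2)c2ccc(F)cc2)nc1-c1ccnc(N2CCC2)c1`: compound 2 reaches only a limit of the assay, > 100000 nM.
Compound 3 `O=C(O)Cc1sc(C(c2ccc(F)cc2)c2ccc(F)cc2)nc1-c1ccco1`: compound 3 gives 140 nM.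

Compound 3 holds the lowest of the two numbers measured; the nearest, compound 1, is separated from it by a 2.4-fold lower number from compound 1 to compound 3 (0.39 log units; beyond the scatter), while compound 2 sits at the limit of > 100000 nM in this assay, at which 1 of the 3 values shown sits, rather than at a number. Compound 4 `O=C(O)Cc1sc(C(c2ccc(F)cc2)c2ccc(F)cc2)nc1-c1ccnc(N2CCCC2)c1` has not been measured; it differs from compound 3 by 2-(pyrrolidin-1-yl)pyridin-4-yl in place of furan-2-yl on an aromatic carbon. The step that bears on this change is an at least 710-fold lower number from compound 2 to compound 3 (2.85 log units; beyond the scatter): compound 2 carries a 2-(azetidin-1-yl)pyridin-4-yl group, close to the 2-(pyrrolidin-1-yl)pyridin-4-yl group that enters compound 4. A large rise is therefore expected, a 710-fold higher number from compound 3 to compound 4 (2.85 log units; beyond the scatter). Compound 4 is estimated at 100000 nM, between 20000 nM and 300000 nM, with a fair chance that only a limit is reported.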

Compound 4, half-maximal inhibitory concentration: > 100000 nM
Compound 4: a limit, no number; the forecaster's own chance of this, stated with the estimate: 70%; the middle value lies on the limit itself.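

Compound 4 shows that the loss seen with compound 2 is not tied to azetidin-1-yl alone: with pyrrolidin-1-yl on the same pyridin-4-yl ring, this assay again returns a limit, not a number. Against the other groups at this position, the change gives an at least 710-fold higher number from compound 3 to compound 4 (2.85 log units; beyond the scatter), and an at least 290-fold higher number from compound 1 to compound 4 (2.46 log units; beyond the scatter). Compound 2 and compound 4 are both limits, and the step between them cannot be read: the limit of > 100000 nM in this assay, at which 2 of the 4 values shown sit.

Going by these compounds, it stays open whether the pyridine ring or the cyclic amine on it accounts for the loss. An unsubstituted pyridin-4-yl group or a 2-methoxypyridin-4-yl group would help separate the two.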